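The compounds below may be only part of what the source reports. "The series", "measured", "known", "first", "only" and "open" are said of these compounds alone.

In an ADME assay on THP-1 cells (Homo sapiens) for cytotoxicity, read by flow cytometry and propidium iodide staining, with a stated time of 72 h (on this read-out higher numbers stand for weaker inhibition and lower numbers for stronger inhibition), compound 2 `Cc1nc2ccc(NC=C3C(=O)OC(C)(C)OC3=O)cc2s1` gives only a limit, > 250000 nM. Compound 1 `CC1(C)OC(=O)C(=CNc2ccc3[nH]nnc3c2)C(=O)O1` also gives only a limit in this assay, > 500000 nM. Both results sit at the edge of what the assay reports, as the limit of > 250000 nM in this assay, at which 1 of the 2 values shown sits, and the limit of > 500000 nM in this assay, at which 1 of the 2 values shown sits, show, so compound 2 cannot be placed against compound 1 beyond that. Compound 3 `CC1(C)OC(=O)C(=CNc2ccc3ncsc3c2)C(=O)O1` differs from compound 2 by hydrogen in place of methyl on an aromatic carbon. Among the measured compounds shown here, no step between measured compounds is available to guide the expectation. Compound 3 is expected to stay inert in this assay, with the estimated step that the limit leaves unreadable from compound 2 to compound 3 being no change beyond the scatter. Compound 3 is estimated at 300000 nM, in a range from 100000 nM to 1000000 nM, most likely reported again as a limit.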

Compound 3, half-maximal inhibitory concentration: > 500000 nM
Compound 3: no number, only a limit; the forecaster's own chance of this, stated with the estimate: 85%; at least 1.6-fold (0.22 log units) between middle value and limit.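

Compound 2 and compound 3 both give only limits in this assay, so no step can be read between them. The compounds shown leave open whether hydrogen in place of methyl on an aromatic carbon changes the read-out at all.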